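The source may hold more compounds than are shown below. What is called first, only, known or untested is meant among the compounds shown, and "the series" means these compounds.

In a functional assay on CWR22R cells (Homo sapiens) for antiproliferative activity, read by colorimetric assay and sulforhodamine B assay, with a stated time of 72 h (a higher number here means a weaker inhibitor, a lower number a stronger inhibitor), compound 1 `COc1ccc(Cn2nnc(O)c2C(=O)Nc2cccc(C(F)(F)F)c2)cc1OC` reads 59200 nM and compound 2 `Oc1noc2cccc(Nc3cccc(C(F)(F)F)c3)c12` reads 64800 nM as its value, so the two stand level within the scatter. Compound 3 `Oc1noc2cccc(Nc3cc(C(F)(F)F)cc(C(F)(F)F)c3)c12` is compound 2 with trifluoromethyl in place of hydrogen on an aromatic carbon, meta to a trifluoromethyl group, a change counted as trifluoromethyl in place of hydrogen on an aromatic carbon in the comparison of the two structures. For the measured compounds named here, no measured pair shows what such a change does in this assay, and the expectation therefore rests on little. A small move towards a stronger inhibitor is expected, and a result within the scatter would be no surprise. The estimated size of a 1.9-fold lower number from compound 2 to compound 3 (0.27 log units; within the scatter) is only modest. For compound 3 the estimated value is 35000 nM with an expected range from 12000 nM to 90000 nM on repeated measurement.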

Compound 3, half-maximal inhibitory concentration: 26700 nM
Estimate against measurement, compound 3: 1.3-fold (0.12 log units) above; the range from low to high includes it.
By their numbers in this assay, from the lowest: compound 3; then compounds 1 and 2 (each within the scatter of the next).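

For the compounds shown here, the first readable step falls at this position: in this assay, trifluoromethyl in place of hydrogen on an aromatic carbon, meta to a trifluoromethyl group, gives a 2.4-fold lower number from compound 2 to compound 3 (0.39 log units; beyond the scatter). The six-membered aromatic ring of carbon only therefore accepts a second trifluoromethyl at this position without any loss, and the gain lies beyond the scatter, although it is modest and rests on a single pair. Nothing shown gives a measured basis for explaining the step.

Still open, from the compounds shown here alone, is whether a nitrile, an amine or a carboxylic acid at the same position would move the number in the same direction as trifluoromethyl. Also open, going by these compounds, is whether the change would carry over to the core of compound 1.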